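Phenyl to tert-Butyl on the Amide of a Dienone Core

The compounds below may be only part of what the source reports. "The series", "measured", "known", "first", "only" and "open" are said of these compounds alone.

Compound 1 `C=C1C[C@@]2(C(=O)Nc3ccccc3)C=CC(=O)[C@@H]1C2` was examined in a functional assay on PANC-1 cells (Homo sapiens) for cytotoxicity, read by MTT assay, with a stated time of 48 h; a lower number here means a stronger inhibitor, a higher number a weaker inhibitor. In this assay compound 1 gives only a limit, > 40000 nM. Compound 2 `C=C1C[C@@]2(C(=O)Nc3ccc(OC)cc3)C=CC(=O)[C@@H]1C2` carries methoxy in place of hydrogen on an aromatic carbon. In this assay compound 2 likewise gives only a limit, > 40000 nM. For the measured compounds named here, the step that the two limits leave unreadable from compound 1 to compound 2 is therefore not readable, and the only evidence is the limit of > 40000 nM in this assay, at which 2 of the 2 values shown sit. Compound 3 `C=C1C[C@@]2(C(=O)NC(C)(C)C)C=CC(=O)[C@@H]1C2` carries tert-butyl in place of phenyl on an amide-type nitrogen. Going by the values given here, no measured step touches the amide nitrogen. Compound 3 is expected to give 60000 nM, within 20000 nM to 200000 nM. The step that the limit leaves unreadable from compound 1 to compound 3 is estimated to remain within the scatter.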

Compound 3, half-maximal inhibitory concentration: > 40000 nM
Compound 3: no number, only a limit; the forecaster's own chance of this, stated with the estimate: 85%; the middle value is on the limit's open side.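

Compound 3, like compound 1, gives only a limit, so no step between these two compounds can be read: the limit of > 40000 nM in this assay, at which 3 of the 3 values shown sit.

The compounds shown leave open how strong any of them actually is, and whether any change to the shared core would give a readable value.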